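The compounds below may be only part of what the source reports. "The series", "measured", "known", "first", "only" and "open" are said of these compounds alone.

Of the compounds shown here, three have so far been measured in a functional assay on CHO cells for agonist activity at Free fatty acid receptor 1 (Homo sapiens), read by FLIPR and calcium flux; a lower number here means that less compound is needed, a higher number that more compound is needed for the effect. Compound 1 `Cc1cccc(C)c1-c1cccc(COc2ccc(S(=O)(=O)CC(=O)O)cc2)c1` gives 66.1 nM in this assay. Compound 2 `COc1cc(C)c(-c2cccc(COc3ccc4c(c3)C(=O)CC4CC(=O)O)c2)c(C)c1` gives 234 nM, and compound 3 `COc1cc(C)c(-c2cccc(COc3ccc4c(c3)C(O)CC4CC(=O)O)c2)c(C)c1` gives 550 nM. Of these three numbers compound 1 holds the lowest, so it needs the least material for the effect; compound 2 stands nearest to it and compound 3 furthest, both differences lying beyond the usual scatter. Compound 4 `COCCOc1cc(C)c(-c2cccc(COc3ccc(S(=O)(=O)CC(=O)O)cc3)c2)c(C)c1` has not yet been measured. It differs from compound 1 by 2-methoxyethoxy in place of hydrogen on an aromatic carbon: a 2-methoxyethoxy group takes the place of a hydrogen atom on the ring that carries two methyl groups. Within the data shown here, no measured pair shows this single change on its own, so its effect has to be estimated. Compounds 2 and 3 carry a methoxy group on a ring of that kind, but they also have a different core, so they say little about this step by itself. The step from compound 1 to compound 4 is expected to be small, a 1.2-fold lower number from compound 1 to compound 4 (0.08 log units; within the scatter), within the scatter. Compound 4 is estimated at 55 nM, with a range from 20 nM to 150 nM.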

Compound 4, half-maximal effective concentration: 126 nM
The estimate for compound 4 lay 2.3-fold (0.36 log units) below the measured number, within the range that was stated.
By their numbers in this assay, from the lowest: compounds 1, 4 and 2 (each within the scatter of the next, the first and the last beyond it); then compound 3.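

In this assay, placing a 2-methoxyethoxy group on the ring with two methyl groups, in the position meta to both methyl groups and para to a large group, gives a 1.9-fold higher number from compound 1 to compound 4 (0.28 log units; within the scatter). This step lies within the scatter, so the measurement shows no clear change even though five heavy atoms and two hydrogen-bond acceptors enter where only a hydrogen stood. Compounds 2 and 3 could not show this, as their core differs from that of compound 1, and no data at hand explain why the step is this small.

As far as these compounds go, it remains open whether this position would accept other groups equally well, such as an amine or a carboxylic acid at the end of the chain. A longer chain, or a plain methoxy group on the core of compound 1, is also left untested by the compounds shown.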